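The source may hold more compounds than are shown below. What is called first, only, known or untested is meant among the compounds shown, and "the series" means these compounds.

Working notes on the series. Among the compounds with values here, in a functional assay on HCT-116 cells (Homo sapiens) for cytotoxicity, read by MTT assay, with a stated time of 72 h (on this read-out higher numbers stand for weaker inhibition and lower numbers for stronger inhibition), compound 1 (`O=C(Nc1ccccc1)Nc1ccc(C(=O)NO)cc1`) gives 14700 nM, while compound 2 (`O=C(/C=C/c1ccc(NC(=O)Nc2ccccc2)cc1)NO`) gives 6490 nM, the lower of the two numbers so far. The next change leads to compound 3 (`O=C(CCc1ccc(NC(=O)Nc2ccccc2)cc1)NO`), with 2-(hydroxycarbamoyl)ethyl in place of 2-(hydroxycarbamoyl)ethenyl on an aromatic carbon, para to a large group: 2-(hydroxycarbamoyl)ethyl in place of 2-(hydroxycarbamoyl)ethenyl on an aromatic carbon. Within the data shown here, only one measured step bears on this, the modest 2.3-fold lower number from compound 1 to compound 2 (0.36 log units; beyond the scatter), which put 2-(hydroxycarbamoyl)ethenyl in place of hydroxycarbamoyl. Among the measured compounds shown here, no measured pair isolates the loss of the chain double bond, so this step is only a loose guide. In this assay, for the measured compounds named here, a small move towards a higher number is expected, probably no larger than that step and quite possibly within the scatter. Compound 3 is estimated at 9000 nM, with an expected range from 3500 nM to 22000 nM. This corresponds to an expected 1.4-fold higher number from compound 2 to compound 3 (0.14 log units; within the scatter).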

Compound 3, half-maximal inhibitory concentration: 16200 nM
Compound 3: middle estimate off by 1.8-fold (0.26 log units), on the low side; the range from low to high includes it.
By their numbers in this assay, from the lowest: compound 2; then compounds 1 and 3 (each within the scatter of the next).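

In this assay, the double bond of the chain matters at this position, on an aromatic carbon para to a large group: 2-(hydroxycarbamoyl)ethyl in place of 2-(hydroxycarbamoyl)ethenyl gives a step beyond the scatter (a 2.5-fold higher number from compound 2 to compound 3 (0.40 log units; beyond the scatter)). Set against hydroxycarbamoyl directly on the aromatic carbon, 2-(hydroxycarbamoyl)ethyl brings no change beyond the scatter (a 1.1-fold higher number from compound 1 to compound 3 (0.04 log units; within the scatter)), so among these compounds only the chain that keeps its double bond stands apart from the directly attached group. Nothing available accounts for this difference between the two chains.

Still open, on these data alone, is whether a longer chain carrying the hydroxycarbamoyl end, with or without a double bond, would follow the same trend. Also open, as far as these compounds go, is how a carboxylic acid in place of hydroxycarbamoyl would behave on the ethenyl chain.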